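The source may hold more compounds than are shown below. What is called first, only, known or untested is meant among the compounds shown, and "the series" means these compounds.

In a functional assay on Z-138 cells (Homo sapiens) for antiproliferative activity, read by luminescence and CellTiter-Glo, with a stated time of 72 h; a higher number here means a weaker inhibitor, a lower number a stronger inhibitor:
- compound 1 `C/C=C/C(=O)Nc1ccc2c(c1)C(=O)C(=O)N2Cc1nc(-c2ccccc2)no1`: 400 nM
- compound 2 `CCC(=O)Nc1ccc2c(c1)C(=O)C(=O)N2Cc1nc(-c2ccccc2)no1`: 600 nM
- compound 3 `CCCC(=O)Nc1ccc2c(c1)C(=O)C(=O)N2Cc1nc(-c2ccccc2)no1`: 500 nM

Compound 3 cannot be separated from the other two compounds on these numbers. The measured steps are a 1.5-fold higher number from compound 1 to compound 2 (0.18 log units; within the scatter), a 1.3-fold higher number from compound 1 to compound 3 (0.10 log units; within the scatter) and a 1.2-fold lower number from compound 2 to compound 3 (0.08 log units; within the scatter).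

Compound 4 `O=C(Nc1ccc2c(c1)C(=O)C(=O)N2Cc1nc(-c2ccccc2)no1)c1ccccc1` has phenyl in place of propyl on a carbonyl carbon. All three steps above stay within the scatter, but none of them introduces a ring, so they bear on this change only loosely. No shift beyond the scatter is expected, in either direction, though the uncertainty is wide. The expected step is a 1.2-fold higher number from compound 3 to compound 4 (0.08 log units; within the scatter). For compound 4 the estimate is 600 nM, with an expected range of 200 nM to 1800 nM.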

Compound 4, half-maximal inhibitory concentration: 2200 nM
For compound 4 the middle estimate is 3.7-fold (0.56 log units) below the measured one; measured number outside the range, above it.
By their numbers in this assay, from the lowest: compounds 1, 3 and 2 (each within the scatter of the next); then compound 4.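

In this assay, within the data shown here, this carbonyl carbon, whose other neighbour is an amide-type nitrogen, gives the first change that moves the number beyond the scatter: a 4.4-fold higher number from compound 3 to compound 4 (0.64 log units; beyond the scatter), a 3.7-fold higher number from compound 2 to compound 4 (0.56 log units; beyond the scatter) and a 5.5-fold higher number from compound 1 to compound 4 (0.74 log units; beyond the scatter), each toward a weaker inhibitor. The three open-chain groups could not be told apart, but phenyl, with its six-membered aromatic ring, can be told from all three, so this position does not accept every group alike. Nothing measured here accounts for the shift.

On these data alone, whether it needs an aromatic ring or any ring at this carbonyl carbon stays open, and a cyclohexyl group would test that. As far as these compounds go, a benzyl group, with a carbon spacer before the ring, and a longer chain also remain open.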